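The source may hold more compounds than are shown below. What is called first, only, known or untested is meant among the compounds shown, and "the series" means these compounds.

Measured so far:
compound 1 `COc1cc(-c2cc(/C=C/C(=O)c3ccccc3)nc3cc(-c4ccccc4)nn23)cc(OC)c1OC` gives 34300 nM;
compound 2 `COc1cc(-c2cc(/C=C/C(=O)c3ccc(C)c(C)c3)nc3cc(-c4ccccc4)nn23)cc(OC)c1OC` gives 15400 nM;
compound 3 `COc1ccc(/C=C/C(=O)c2cc(-c3cc(OC)c(OC)c(OC)c3)n3nc(-c4ccccc4)cc3n2)cc1` gives 16900 nM.

All three were tested in a functional assay on DU-145 cells (Homo sapiens) for antiproliferative activity, read by MTT assay, with a stated time of 24 h; on this read-out higher numbers stand for weaker inhibition and lower numbers for stronger inhibition. Compound 3 holds the second highest number of the three; its nearest neighbour is compound 2, with a step of a 1.1-fold higher number from compound 2 to compound 3 (0.04 log units; within the scatter), and its furthest is compound 1, with a step of a 2.0-fold lower number from compound 1 to compound 3 (0.31 log units; beyond the scatter).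

Compound 4 `COc1cc(-c2cc(/C=C/C(=O)c3ccc(Cl)cc3)nc3cc(-c4ccccc4)nn23)cc(OC)c1OC` is the next compound. The change from compound 3 is 2-((4-chlorophenyl)carbonyl)ethenyl in place of (2-(4-methoxyphenyl)ethenyl)carbonyl on an aromatic carbon, on an aromatic carbon of the shared core, next to the ring nitrogen and meta to a 3,4,5-trimethoxyphenyl group. Compound 4 therefore carries the carbonyl arm in the same sense as compound 1 and compound 2, with a 4-chlorophenyl on the carbonyl carbon. Among the compounds with values here, the steps that bear on it are a 2.2-fold lower number from compound 1 to compound 2 (0.35 log units; beyond the scatter), where a substituted phenyl on the carbonyl carbon gave a modestly lower number, and a 2.0-fold lower number from compound 1 to compound 3 (0.31 log units; beyond the scatter). Both were modest, so a small step in this assay, or none beyond the scatter, is expected: a 1.1-fold higher number from compound 3 to compound 4 (0.03 log units; within the scatter). Compound 4 is estimated at 18000 nM, within 8000 nM to 45000 nM.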

Compound 4, half-maximal inhibitory concentration: 29300 nM
For compound 4 the middle estimate is 1.6-fold (0.21 log units) below the measured one; low and high end bracket the measured number.
By their numbers in this assay, from the lowest: compounds 2, 3, 4 and 1 (each within the scatter of the next, the first and the last beyond it).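

In this assay, chloro in place of hydrogen on the phenyl of the carbonyl arm gives a step within the scatter (a 1.2-fold lower number from compound 1 to compound 4 (0.07 log units; within the scatter)), whereas the 3,4-dimethylphenyl of compound 2 gave a step beyond it (a 2.2-fold lower number from compound 1 to compound 2 (0.35 log units; beyond the scatter)), so a substituent on this ring does not always give such a step. The steps to the other two neighbours also stay within the scatter, both for 4-chlorophenyl in place of 3,4-dimethylphenyl (a 1.9-fold higher number from compound 2 to compound 4 (0.28 log units; within the scatter)) and for the 2-((4-chlorophenyl)carbonyl)ethenyl arm in place of (2-(4-methoxyphenyl)ethenyl)carbonyl (a 1.7-fold higher number from compound 3 to compound 4 (0.24 log units; within the scatter)). Nothing available explains why chloro and the two methyl groups behave differently here.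

The compounds shown leave open whether an amine or a carboxylic acid on this phenyl would give a step beyond the scatter. They also leave open what a longer chain between the carbonyl and the shared core would do.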